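The source may hold more compounds than are shown below. What is called first, only, known or untested is meant among the compounds shown, and "the series" means these compounds.

Compound 3 `OCc1cccc(C2=NC(c3ccc(F)cc3)(c3ccc(F)cc3)CN2)c1` gives 59 nM in an assay on LM cells for displacement of a labelled ligand from Neuropeptide Y receptor type 5 (Homo sapiens) (a lower number here means a stronger inhibitor, a higher number a weaker inhibitor), the highest of the three numbers recorded. Compound 1 `Fc1ccc(C2(c3ccc(F)cc3)CNC(c3cccc(Br)c3)=N2)cc1` gives 4.8 nM and compound 2 `O=Cc1cccc(C2=NC(c3ccc(F)cc3)(c3ccc(F)cc3)CN2)c1` gives 8.7 nM in this assay. The recorded steps show a 12-fold higher number from compound 1 to compound 3 (1.09 log units; beyond the scatter) and a 6.8-fold higher number from compound 2 to compound 3 (0.83 log units; beyond the scatter), whereas there was only a 1.8-fold higher number from compound 1 to compound 2 (0.26 log units; within the scatter). Compound 4 `N#Cc1cccc(C2=NC(c3ccc(F)cc3)(c3ccc(F)cc3)CN2)n1` differs from compound 3 by 6-cyanopyridin-2-yl in place of 3-(hydroxymethyl)phenyl on a carbon with a double bond to nitrogen. Among the measured compounds shown here, no measured step covers a change of this kind, since the three measured compounds share the same ring of carbon only and differ in a single group on it. As far as these compounds go, the two steps that bear on it show that compound 3 sits well above both neighbours, so the loss of the hydroxymethyl is expected to bring the number down by roughly the size of those steps, while the ring nitrogen and the nitrile are untested and widen the range. Compound 4 is therefore expected to show a 5.9-fold lower number from compound 3 to compound 4 (0.77 log units; beyond the scatter), to an estimated 10 nM, within 2 nM to 60 nM in this assay.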

Compound 4, half-maximal inhibitory concentration: 39 nM
The estimate for compound 4 lay 3.9-fold (0.59 log units) below the measured number; the measured number falls inside the stated range.
By their numbers in this assay, from the lowest: compounds 1 and 2 (each within the scatter of the next); then compounds 4 and 3 (each within the scatter of the next).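

In this assay, among the compounds shown here, the position on a carbon with a double bond to nitrogen accepts a change of the whole aryl group, not only of the single group on the ring of carbon: 6-cyanopyridin-2-yl in place of 3-(hydroxymethyl)phenyl stays within the scatter (a 1.5-fold lower number from compound 3 to compound 4 (0.18 log units; within the scatter)). The same ring does not match the 3-formylphenyl and 3-bromophenyl compounds, as the steps beyond the scatter show (a 4.5-fold higher number from compound 2 to compound 4 (0.65 log units; beyond the scatter); an 8.1-fold higher number from compound 1 to compound 4 (0.91 log units; beyond the scatter)). Nothing available explains why these groups differ in this way. Since the ring nitrogen and the nitrile enter together, their separate contributions remain unresolved. A phenyl ring bearing a nitrile, pyridin-2-yl without the nitrile, and a pyridine ring carrying bromo, formyl or an amine would separate them.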